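Aminoalkyl oxadiazoles: ring amine versus primary amine

The source may report more compounds than this note shows. Statements on the series, on what has been measured and on what is new or still open speak of the compounds shown alone.

Compounds measured in an assay on HeLa cells for inhibition of sphingosine-1-phosphate transporter SPNS2 (Mus musculus), read by LC-MS, tested at 2 uM (a higher number here means more inhibition at the concentration tested (going by the name of the read-out), a lower number less inhibition), so far:
compound 1 `CCCCCCCCCCc1ccc(-c2noc(CN)n2)cc1` gives 62%
compound 2 `CCCCCCCCCCc1ccc(-c2noc(CCCN)n2)cc1` gives 67%
compound 3 `CCCCCCCCCCc1ccc(-c2noc([C@@H]3CCCN3)n2)cc1` gives 21%

Compound 3 stands lowest of the three; the steps of a number 41 percentage points lower from compound 1 to compound 3 (beyond the scatter) and a number 46 percentage points lower from compound 2 to compound 3 (beyond the scatter) are both large and beyond the scatter, while a number 5 percentage points higher from compound 1 to compound 2 (within the scatter) is within it.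

Compound 4 `CCCCCCCCCCc1ccc(-c2noc([C@@H]3CC[C@H](N)C3)n2)cc1` is not yet measured. It differs from compound 3 by 3-aminocyclopentyl in place of pyrrolidin-2-yl on an aromatic carbon. Within the data shown here, no measured step covers this change directly. Because a number 41 percentage points lower from compound 1 to compound 3 (beyond the scatter) and a number 46 percentage points lower from compound 2 to compound 3 (beyond the scatter) show that moving the nitrogen out of an open primary amine into the pyrrolidin-2-yl ring cost much, the reverse direction, a primary amine restored on a 3-aminocyclopentyl, is expected to recover part of that loss, so a rise a number 27 percentage points higher from compound 3 to compound 4 (beyond the scatter) is expected in this assay. Compound 4 is therefore estimated at 48%, within 25% to 72%.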

Compound 4, a percentage reported as inhibition, at one concentration (the size of the read-out at that concentration, not a potency): 38%
Compound 4: middle estimate off by 10 percentage points, on the high side; the measured number falls inside the stated range.
By their numbers in this assay, from the lowest: compound 3; then compound 4; then compounds 1 and 2 (each within the scatter of the next).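

In this assay, swapping pyrrolidin-2-yl for 3-aminocyclopentyl gives a number 17 percentage points higher from compound 3 to compound 4 (beyond the scatter), so a primary amine on a carbon-only ring recovers part of the loss at this position. The open chains are not matched, with a number 29 percentage points lower from compound 2 to compound 4 (beyond the scatter) and a number 24 percentage points lower from compound 1 to compound 4 (beyond the scatter), so a primary amine alone does not restore the earlier level here. No measured evidence accounts for these steps. Open, on these data alone, is whether a piperidin-4-yl group would track pyrrolidin-2-yl, and whether the other stereoisomers of 3-aminocyclopentyl would give the same number.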